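A few compounds are considered here, and "the series" means these few. Any claim that something is new, unique, unknown or untested is made for them only; others in the source may bear on it.

Measured so far in a functional assay on U-87MG ATCC cells for cytotoxicity against U-87 MG (Homo sapiens), read by MTT assay, with a stated time of 72 h; a higher number here means a weaker inhibitor, a lower number a stronger inhibitor:
compound 1 `O=C(Nc1nc2ccc(Cl)cc2s1)c1cn(-c2ccccc2)nc1-c1ccccc1` — 4980 nM
compound 2 `Cc1ccc2nc(NC(=O)c3cn(-c4ccccc4)nc3-c3ccccc3)sc2c1` — 23200 nM

Among the compounds with values here, compound 2 stands at the highest of the two numbers in this assay, its nearest neighbour being compound 1; the one measured step, a 4.7-fold higher number from compound 1 to compound 2 (0.67 log units; beyond the scatter), is modest but beyond the scatter. Compound 3 `Cc1ccc2nc(NC(=O)c3cn(-c4ccccc4)nc3-c3ccc(F)cc3)sc2c1` has not been measured. It differs from compound 2 by fluoro in place of hydrogen on an aromatic carbon. Within the data shown here, no measured step bears on this change: the single step available concerns the substituent on the shared core, not the phenyl ring that carries the new fluoro. Among the measured compounds shown here, a small fluoro added on an aromatic carbon of this kind, with no precedent, gives no ground to expect a step beyond the scatter in either direction, so compound 3 is expected to sit close to compound 2, at a 1.2-fold lower number from compound 2 to compound 3 (0.06 log units; within the scatter). The estimate for compound 3 is 20000 nM, expected between 7000 nM and 60000 nM.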

Compound 3, half-maximal inhibitory concentration: > 50000 nM
Compound 3 ended at the assay's limit; the forecaster's own chance of this, stated with the estimate: 15%; at least 2.5-fold (0.39 log units) between middle value and limit.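

In this assay compound 3 gives > 50000 nM, a limit of the assay and not a number. The phenyl ring, untouched by the earlier step, proves sensitive to a single added atom: phenyl to 4-fluorophenyl, with fluoro para to a large group, gives an at least 2.1-fold higher number from compound 2 to compound 3 (0.33 log units; beyond the scatter), a change beyond the scatter and opposite in direction to what a neutral swap would allow. This step is only a bound, and its full size cannot be read: the limit of > 50000 nM in this assay, at which 1 of the 3 values shown sits.

The compounds shown carry no other group at this place, such as an amine or a carboxylic acid, so it stays open whether the weakening belongs to fluoro alone or to any substituent here. Going by these compounds, whether 4-fluorophenyl acts alike with chloro in place of methyl on the shared core, as in compound 1, also stays open.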